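The source may report more compounds than this note shows. Statements on the series, on what has been measured and on what is new or still open speak of the compounds shown alone.

The measured compounds:
Compound 1, `CC(C)CCOC(=O)C(O)Cn1cnc2c(N)ncnc21`, gives 400 ug/mL in a functional assay on Vero cells (Chlorocebus sabaeus) for cytotoxicity; on this read-out higher numbers stand for lower toxicity in this test and lower numbers for higher toxicity in this test.
Compound 2, `CCCOC(=O)C(O)Cn1cnc2c(N)ncnc21`, gives > 400 ug/mL in this assay, which is a limit of the assay rather than a number.
Compound 3, `CCC(C)OC(=O)C(O)Cn1cnc2c(N)ncnc21`, gives > 400 ug/mL in this assay, again a limit rather than a number.

Compound 1 thus stands at the only number shown in this assay; the other two values are limits, and the limit of > 400 ug/mL in this assay, at which 2 of the 3 values shown sit, marks where they sit. Compound 4, `Nc1ncnc2c1ncn2CC(O)C(=O)OC1CCCCC1`, has not yet been measured. It differs from compound 1 in one place: cyclohexyl in place of isopentyl on an oxygen next to a carbonyl group. Two measured steps alter the same part of the molecule. The step of a number no lower from compound 1 to compound 3 (the limit leaves the size open) and the step of a number no lower from compound 1 to compound 2 (the limit leaves the size open) both change the group on the oxygen next to a carbonyl group, and because of the limit of > 400 ug/mL in this assay, at which 2 of the 3 values shown sit, neither has a readable size. The step that the two limits leave unreadable from compound 2 to compound 3 is unreadable as well. What these steps do show is that three different groups at this position leave every value at the limit or at a number equal to it, so the expected step of no change at the digits printed from compound 1 to compound 4 (within the scatter) is none beyond the scatter, with a real chance that only a limit is reported. Compound 4 is therefore estimated at 400 ug/mL, within 200 ug/mL to 800 ug/mL.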

Compound 4, minimum cytotoxic concentration: 100 ug/mL
For compound 4 the middle estimate is 4.0-fold (0.60 log units) above the measured one; measured number outside the range, below it.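

In this assay, the group on the oxygen next to a carbonyl group proves able to shift the read-out: the change from isopentyl to cyclohexyl gives a 4.0-fold lower number from compound 1 to compound 4 (0.60 log units; beyond the scatter), a step of readable size at this position. Cyclohexyl also gives an at least 4.0-fold lower number from compound 3 to compound 4 (0.60 log units; beyond the scatter) in place of sec-butyl and an at least 4.0-fold lower number from compound 2 to compound 4 (0.60 log units; beyond the scatter) in place of propyl, so among these four compounds the one carrying a six-membered ring of carbon only has the lowest number, which on this read-out stands for the highest toxicity in this test. The last two steps have only a lower bound on their size because each starts from a limit rather than a number: the limit of > 400 ug/mL in this assay, at which 2 of the 4 values shown sit.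

The compounds shown cannot separate the presence of a ring from the carbon count of the group, as cyclohexyl is the only ring among them. They also leave open how a cyclopentyl group, a phenyl group or a longer chain such as octyl on this oxygen would read, and how far compound 2 and compound 3 lie beyond their limit.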